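The source may hold more compounds than are shown below. What is called first, only, known or untested is meant among the compounds shown, and "the series" means these compounds.

Measured so far:
compound 1, `COc1ccc(CNc2ncc(C(=O)O)c3nc(-c4ccco4)nn23)cc1OC`, 159 nM
compound 2, `CCOC(=O)c1cnc(NCC2CCCCC2)n2nc(-c3ccco3)nc12`, 41.2 nM
compound 3, `CNc1ncc(C(=O)O)c2nc(-c3ccco3)nn12`, 15900 nM

Compound 3 stands at the highest number of the three in an assay on CHO cells for displacement of a labelled ligand from adenosine receptor A3 (Homo sapiens) (on this read-out lower numbers stand for stronger inhibition and higher numbers for weaker inhibition), and is the weakest of the set; compound 1 sits at a much lower number and compound 2 lower still. Compound 4 `O=C(O)c1cnc(NCc2ccc(F)cc2)n2nc(-c3ccco3)nc12` differs from compound 3 by 4-fluorophenyl in place of hydrogen on a saturated chain carbon bound to a nitrogen on an aromatic ring. Compound 1, carrying a substituted benzyl on the same nitrogen with the acid kept, gives 159 nM, far lower than compound 3. A comparable effect is therefore expected here: a large downward step from compound 3 to compound 4, a 110-fold lower number from compound 3 to compound 4 (2.03 log units; beyond the scatter), is estimated in this assay. For compound 4 the expected value is 150 nM, with a range from 40 nM to 600 nM.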

Compound 4, inhibition constant: 14000 nM
Compound 4: the middle estimate sits 93-fold (1.97 log units) below what was measured; the whole stated range lies below it.
By their numbers in this assay, from the lowest: compound 2; then compound 1; then compounds 4 and 3 (each within the scatter of the next).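

In this assay, 4-fluorophenyl in place of hydrogen on a saturated chain carbon bound to a nitrogen on an aromatic ring gives a 1.1-fold lower number from compound 3 to compound 4 (0.06 log units; within the scatter), so with the acid kept, a benzyl group as such does not separate compound 4 from the methyl compound. The substituents on the phenyl ring now matter, since compound 1 stands at 159 nM and compound 4 at 14000 nM with only those substituents differing. No evidence shown explains this difference.

Open, as far as these compounds go, is whether a plain benzyl or a 4-chlorobenzyl on this nitrogen would read like compound 4 or like compound 1.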